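A Trifluoromethyl Group Joins the Aromatic Ring

The compounds below may be only part of what the source reports. "The series", "measured", "known", "first", "only" and "open" are said of these compounds alone.

Compound 1, `O=C(CCCCC(S)CCS)Nc1ccccc1`: 7.37%
Compound 2, `O=C(CCCCC(S)CCS)Nc1ccc(F)cc1`: 8.11%

Both were measured in a functional assay on HO8910 cells (Homo sapiens) for inhibition, read by MTT assay, with a stated time of 24 h, tested at 0.1 ug/mL; on this read-out higher numbers stand for more inhibition of growth at the one concentration tested and lower numbers for less inhibition of growth. Compound 1 stands lowest of the two numbers, and its nearest neighbour is compound 2, with a step of a number 0.7 percentage points higher from compound 1 to compound 2 (within the scatter) that lies within the scatter. Compound 3, `O=C(CCCCC(S)CCS)Nc1cccc(C(F)(F)F)c1`, differs from compound 1 by trifluoromethyl in place of hydrogen on an aromatic carbon. For the measured compounds named here, the one measured step that bears on it, a number 0.7 percentage points higher from compound 1 to compound 2 (within the scatter), also put fluoro in place of hydrogen on an aromatic carbon and stayed within the scatter, so in this assay no step beyond the scatter is expected in either direction. The expected step of a number 1.1 percentage points higher from compound 1 to compound 3 (within the scatter) is therefore small. Compound 3 is estimated at 8.5%, within 0% to 20%.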

Compound 3, percent growth inhibition at one concentration: 10.8%
Compound 3: the middle estimate sits 2.3 percentage points below what was measured; the measured number falls inside the stated range.
By their numbers in this assay, from the lowest: compounds 1, 2 and 3 (each within the scatter of the next).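

In this assay, putting trifluoromethyl on an aromatic carbon, meta to a large group, gives a number 3.4 percentage points higher from compound 1 to compound 3 (within the scatter). So a group of 4 heavy atoms at this place leaves the number inside the scatter, which the single fluoro of compound 2 could not show. No measurement here offers an explanation for this small step.

On these data alone, whether an amine or a carboxylic acid at this place would move the number beyond the scatter remains open. So does the effect of trifluoromethyl on the ring's other carbons.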